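The source may report more compounds than this note shows. Statements on the series, on what has been measured and on what is new or still open speak of the compounds shown alone.

Measured in an ADME assay on HepG2 2.2.15 cells (Homo sapiens) for cytotoxicity, read by MTT assay, with a stated time of 8 days; on this read-out higher numbers stand for lower toxicity in this test and lower numbers for higher toxicity in this test:
- Compound 1 `O=c1c(C2CC2)cc(-c2ccc(F)nc2F)nn1Cc1ccc(Cl)cc1`: 39800 nM
- Compound 2 `O=c1c(CO)cc(-c2ccc(F)nc2F)nn1Cc1ccc(Cl)cc1`: > 100000 nM, a limit of the assay and not a number
- Compound 3 `CC(C)c1cc(-c2ccc(F)nc2F)nn(Cc2ccc(Cl)cc2)c1=O`: 56700 nM

Within the data shown here, only two of these values are true numbers, and they do not separate: a 1.4-fold higher number from compound 1 to compound 3 (0.15 log units; within the scatter). Compound 3 therefore stands level with compound 1. Compound 2 is known only as a limit.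

Compound 4 `O=C(O)c1cc(-c2ccc(F)nc2F)nn(Cc2ccc(Cl)cc2)c1=O` carries a carboxy group in place of the isopropyl of compound 3, on the same aromatic carbon, opposite the ring nitrogen (carboxy in place of isopropyl on an aromatic carbon).

Among the measured compounds shown here, no measured step shows this exact exchange. The closest guide is compound 2, whose hydroxymethyl on that carbon also brings oxygen. Replacing cyclopropyl with hydroxymethyl gave a shift beyond the scatter: an at least 2.5-fold higher number from compound 1 to compound 2 (0.40 log units; beyond the scatter). The comparison with isopropyl is less firm: an at least 1.7-fold lower number from compound 2 to compound 3 (0.24 log units; that floor lies within the scatter). Read in reverse, these steps point to a modest rise in this assay for compound 4, meaning lower toxicity in this test, though the guide is a single compound.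

The expected change is a 1.8-fold higher number from compound 3 to compound 4 (0.25 log units; within the scatter). Compound 4 is estimated at 100000 nM, with an expected range from 50000 nM to 200000 nM. The result may also come back only as a limit.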

Compound 4, half-maximal cytotoxic concentration: > 100000 nM
Compound 4: a limit, no number; the forecaster's own chance of this, stated with the estimate: 60%; the middle value sits exactly at the limit.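

In this assay compound 4 gives a limit and not a number, and it joins compound 2 as the second group carrying oxygen on this carbon, opposite the ring nitrogen, to end at the same limit: the limit of > 100000 nM in this assay, at which 2 of the 4 values shown sit.

Putting carboxy in place of cyclopropyl gives an at least 2.5-fold higher number from compound 1 to compound 4 (0.40 log units; beyond the scatter), which means lower toxicity in this test and matches the earlier step seen with hydroxymethyl. Putting carboxy in place of isopropyl gives an at least 1.7-fold higher number from compound 3 to compound 4 (0.24 log units; that floor lies within the scatter), so this exchange has only a floor that stays within the scatter, and the step between the two limits, from compound 2 to compound 4, cannot be read.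

Hydroxymethyl and carboxy therefore remain unranked against each other in this assay, and the separation of both from isopropyl is not firmly established. An amine, a primary amide or a longer chain ending in hydroxyl on this same carbon would test whether the link between oxygen-bearing groups and the limit holds beyond these two compounds.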